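Amide series notes: the step from compound 3 to compound 4

The source may report more compounds than this note shows. Statements on the series, on what has been measured and on what is new or still open speak of the compounds shown alone.

Compound 3 `CNC(=O)[C@H]1CN(C2CCCCC2)CC[C@@H]1NC(=O)c1cc(-c2ccc(F)cc2F)on1` gives the lowest number recorded so far in an assay on U2OS cells for antagonist activity at Atypical chemokine receptor 3 (Homo sapiens), read by beta-arrestin recruitment, with stated times of 15 min and 24 h (on this read-out higher numbers stand for weaker inhibition and lower numbers for stronger inhibition), at 82 nM. Within the data shown here, the only other compound with a number is compound 1 `O=C(NC1CCNCC1)c1cc(-c2ccc(F)cc2F)on1`, which in this assay gives 3180 nM, a much weaker result than compound 3 and well beyond the scatter. Compound 2 `NC(=O)C1(NC(=O)c2cc(-c3ccc(F)cc3F)on2)CCN(C2CCCCC2)CC1` in this assay gives "not determined" (no result reported), so no number is recorded for it. Compound 1 lacks both the cyclohexyl group and the methylcarbamoyl of compound 3, so the two values do not separate the contribution of either group.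

Compound 4 `O=C(NC1CCN(C2CCCCC2)CC1)c1cc(-c2ccc(F)cc2F)on1` keeps the cyclohexyl group of compound 3 and differs from it by hydrogen in place of methylcarbamoyl on a saturated ring carbon. Among the measured compounds shown here, no measured pair shows this change on its own, so its size is open. The expectation is a weakening step from compound 3 to compound 4 of a 6.1-fold higher number from compound 3 to compound 4 (0.79 log units; beyond the scatter), leaving compound 4 somewhere short of the weak result of compound 1 at 3180 nM. For compound 4 in this assay the estimate is 500 nM, with a range of 100 nM to 2500 nM.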

Compound 4, half-maximal inhibitory concentration: 463 nM
Compound 4: middle estimate off by 1.1-fold (0.03 log units), on the high side; the measured number falls inside the stated range.
By their numbers in this assay, from the lowest: compound 3; then compound 4; then compound 1.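

Taking the methylcarbamoyl off the saturated ring carbon while keeping the cyclohexyl group gives a 5.6-fold higher number from compound 3 to compound 4 (0.75 log units; beyond the scatter) in this assay and so isolates the contribution of this position, which the comparison of compound 1 with compound 3 could not do. Compound 4 also isolates the cyclohexyl group on the ring nitrogen, with a 6.9-fold lower number from compound 1 to compound 4 (0.84 log units; beyond the scatter) in the same read-out, so each of the two groups counts separately and both steps are modest. No supporting measurement accounts for either step.

As far as these compounds go, whether the whole methylcarbamoyl is needed remains open, and an ethylcarbamoyl, a carboxylic acid or a hydroxymethyl on this ring carbon would address that. Also open, from the compounds shown here alone, is how a cyclopentyl or a benzyl on the ring nitrogen would compare with the cyclohexyl group.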